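Moving the trifluoromethyl group on the benzylsulfanyl arm

A few compounds are considered here, and "the series" means these few. Any claim that something is new, unique, unknown or untested is made for them only; others in the source may bear on it.

Working notes on the series. Compound 1 `Cc1cc(-c2ccccc2)n(/C(N)=N/S(=O)(=O)c2cc(C)c(Cl)cc2SCc2ccccc2C(F)(F)F)n1` is the weakest of the three measured compounds in a functional assay on HeLa cells (Homo sapiens) for cytotoxicity, read by MTT assay, with a stated time of 72 h; on this read-out higher numbers stand for weaker inhibition and lower numbers for stronger inhibition; compound 1 gives 215000 nM. Compound 2 `Cc1cc(S(=O)(=O)/N=C(\N)n2nccc2-c2ccccc2)c(SCc2cccc(Cl)c2)cc1Cl` gives 10000 nM in this assay, and compound 3 `Cc1ccc(CSc2cc(Cl)c(C)cc2S(=O)(=O)/N=C(\N)n2nccc2-c2ccccc2)cc1` gives 17000 nM. Among the compounds with values here, both carry a core joined differently from that of compound 1, so no single-point step links either to it; their numbers simply stand well apart from the number of compound 1, beyond the scatter in each case. Inside that pair the only measured step is a 1.7-fold higher number from compound 2 to compound 3 (0.23 log units; within the scatter), a swap of the group on a saturated chain carbon bound to a sulfur that left the read-out essentially unchanged.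

Compound 4 `Cc1cc(-c2ccccc2)n(/C(N)=N/S(=O)(=O)c2cc(C)c(Cl)cc2SCc2cccc(C(F)(F)F)c2)n1` is compound 1 with the change (3-(trifluoromethyl)phenyl in place of 2-(trifluoromethyl)phenyl on a saturated chain carbon bound to a sulfur). Within the data shown here, the only measured step at the same place, a 1.7-fold higher number from compound 2 to compound 3 (0.23 log units; within the scatter), stayed within the scatter, though it was made on a different core and exchanged different groups. The expected step is therefore a 1.4-fold lower number from compound 1 to compound 4 (0.16 log units; within the scatter), not clearly beyond the scatter. Compound 4 is estimated at 150000 nM in this assay, with a range of 50000 nM to 500000 nM.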

Compound 4, half-maximal inhibitory concentration: 98000 nM
Beside the measured number, compound 4's estimate is 1.5-fold (0.18 log units) above it; the range from low to high includes it.
By their numbers in this assay, from the lowest: compounds 2 and 3 (each within the scatter of the next); then compound 4; then compound 1.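

On the core of compound 1, the place on a saturated chain carbon bound to a sulfur responds to where the trifluoromethyl group sits on the phenyl ring: in this assay the change gives a 2.2-fold lower number from compound 1 to compound 4 (0.34 log units; beyond the scatter), a modest step. Within the data shown here, the earlier step at this place, a 1.7-fold higher number from compound 2 to compound 3 (0.23 log units; within the scatter), stayed within the scatter, so this is the first reading there that lies beyond it, and it comes from a swap that keeps the same atoms and only joins them differently. No measurement at hand bears on why the read-out moves with this change.

The compounds shown leave open how the 3-chlorophenyl and 4-methylphenyl groups would read on the core of compound 1. They also leave open whether an amine or a carboxylic acid on this phenyl ring would shift the read-out further.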